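Replacing the Oxirane of Compound 2

The source may hold more compounds than are shown below. What is called first, only, known or untested is meant among the compounds shown, and "the series" means these compounds.

Compound 1 `C=C[C@@](C)(/C=C/c1ccc(OS(=O)(=O)c2ccc(C)cc2)cc1)CCC=C(C)C`: > 49000 nM (a limit)
Compound 2 `C=C[C@@](C)(/C=C/c1ccc(O)cc1)CCC1OC1(C)C`: > 49000 nM (a limit)

In a functional assay on Jurkat cells (Homo sapiens) for cytotoxicity, with a stated time of 72 h (a higher number here means that more compound is needed for the effect, a lower number that less compound is needed), compound 2 gives > 49000 nM as a limit and not as a number. Compound 1 likewise gives > 49000 nM as a limit. All that can be said of the pair is the limit of > 49000 nM in this assay, at which 2 of the 2 values shown sit, and nothing finer, so compound 2 has no numerical standing.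

The unmeasured compound 3 `C=C[C@@](C)(/C=C/c1ccc(O)cc1)CC/C=C(\C)CO` has the same atoms as compound 2, joined differently: 2-(hydroxymethyl)prop-1-en-1-yl in place of 3,3-dimethyloxiran-2-yl on a saturated chain carbon, three bonds along the chain from two double-bonded chain carbons. In words, 2-(hydroxymethyl)prop-1-en-1-yl stands in place of 3,3-dimethyloxiran-2-yl on a saturated chain carbon, three bonds along the chain from two double-bonded chain carbons.

Within the data shown here, no measured step is available to size such a change, so the expectation is a cautious one. The expected change in this assay is small, an at least 1.2-fold lower number from compound 2 to compound 3 (0.08 log units; that floor lies within the scatter) in the direction of less compound needed, and another limit is quite possible. For compound 3 the estimated value is 40000 nM with an expected range from 15000 nM to 70000 nM in this estimate.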

Compound 3, half-maximal effective concentration: > 49000 nM
Compound 3: a limit, no number (the forecaster's own chance of this, stated with the estimate: 55%); middle value at least 1.2-fold (0.08 log units) from the limit.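

In this assay compound 3 gives > 49000 nM as a limit and not as a number. Among these compounds, compound 2 also stands at a limit, so no step between compound 2 and compound 3 can be read. The compounds shown leave open whether 2-(hydroxymethyl)prop-1-en-1-yl in place of 3,3-dimethyloxiran-2-yl changes the amount of compound needed at all, since only one limit is on view: the limit of > 49000 nM in this assay, at which 3 of the 3 values shown sit.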